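This account rests on a few compounds, and the source may have more. Where it says the series, first, only, none or still open, it means among the compounds named here.

Measured compounds:
Compound 1, `COc1cc2c(Nc3nc4ccc(C(=O)Nc5c(C)cccc5Cl)cc4s3)ncnc2cc1OCCCN1CCC(C)CC1`, gives 9700 nM in a functional assay on A549 cells (Homo sapiens) for cytotoxicity, read by WST assay, with a stated time of 72 h; on this read-out lower numbers stand for stronger inhibition and higher numbers for weaker inhibition.
Compound 2, `COc1cc2c(Nc3nc4ccc(C(=O)Nc5c(C)cccc5Cl)cc4s3)ncnc2cc1OCCCN1CCCCC1`, gives 12800 nM.
Compound 3, `COc1cc2c(Nc3nc4ccc(C(=O)Nc5c(C)cccc5Cl)cc4s3)ncnc2cc1OCCCN1CCCC1`, gives 38600 nM.

Compound 1 holds the lowest number of the three in this assay, but its nearest neighbour, compound 2, sits within the scatter of it: a 1.3-fold higher number from compound 1 to compound 2 (0.12 log units; within the scatter). Only compound 3 stands clearly apart, with a 4.0-fold higher number from compound 1 to compound 3 (0.60 log units; beyond the scatter) and a 3.0-fold higher number from compound 2 to compound 3 (0.48 log units; beyond the scatter).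

Compound 4, `COc1cc2c(Nc3nc4ccc(C(=O)Nc5c(C)cc(C)cc5C)cc4s3)ncnc2cc1OCCCN1CCC(C)CC1`, differs from compound 1 at the amide-type nitrogen: 2,4,6-trimethylphenyl in place of 2-chloro-6-methylphenyl on an amide-type nitrogen. Going by the values given here, none of the measured steps bears on this part of the molecule; all three of them concern the saturated ring at the far end of the chain, and the carboxamide substituent stays unchanged across compounds 1, 2 and 3. Among the compounds with values here, there is therefore no measured step from which to read a direction, and the expectation for compound 4 is a step of no more than scatter size, a 1.2-fold higher number from compound 1 to compound 4 (0.09 log units; within the scatter), in this assay. Compound 4 is estimated at 12000 nM, within a range from 4000 nM to 36000 nM.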

Compound 4, half-maximal inhibitory concentration: 5400 nM
Compound 4: the middle estimate sits 2.2-fold (0.35 log units) above what was measured, within the range that was stated.
By their numbers in this assay, from the lowest: compounds 4, 1 and 2 (each within the scatter of the next, the first and the last beyond it); then compound 3.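

In this assay, going by these compounds alone, a step of a 1.8-fold lower number from compound 1 to compound 4 (0.25 log units; within the scatter) is the first reading at the amide-type nitrogen, where compounds 1, 2 and 3 all carry 2-chloro-6-methylphenyl. It shows that this position accepts 2,4,6-trimethylphenyl, a group of carbon only that leaves out the chlorine, with the number staying within the scatter of that of compound 1 and this read-out drawing no clear distinction between the two groups. No measurement at hand offers an explanation for this result.

The compounds shown leave open how groups such as 2,6-dichlorophenyl or an unsubstituted phenyl would read on this nitrogen. They also leave open whether 2,4,6-trimethylphenyl would hold the same place with piperidin-1-yl or pyrrolidin-1-yl at the end of the chain.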